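This account rests on a few compounds, and the source may have more. Where it says the series, first, only, none or still open, it means among the compounds named here.

Of the compounds shown here, two have been measured in an assay for binding affinity to Alpha-1B adrenergic receptor (Homo sapiens); on this read-out higher numbers stand for weaker inhibition and lower numbers for stronger inhibition. Compound 1 `O=c1c2ccccc2c(Cc2ccc(Cl)cc2)nn1C1CCCN(Cc2ccc(OCCCN3CCCCCC3)cc2)CC1` gives 126 nM, and compound 2 `CN1CCC[C@@H]1Cn1nc(Cc2cccc(Cl)c2)c2ccccc2c1=O` gives 631 nM, the higher of the two numbers; its gap to compound 1 lies beyond the scatter. Compound 3 `CN1CCC[C@@H]1Cn1nc(Cc2ccc(F)cc2)c2ccccc2c1=O` differs from compound 2 in one place: 4-fluorophenyl in place of 3-chlorophenyl on a saturated chain carbon bound to an aromatic carbon. Within the data shown here, no measured pair shows this kind of exchange, so the expected step of a 1.6-fold higher number from compound 2 to compound 3 (0.20 log units; within the scatter) is taken to be small, toward weaker binding or none beyond the scatter. Compound 3 is therefore expected to give about 1000 nM, with a likely range from 300 nM to 3000 nM.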

Compound 3, inhibition constant: 79.4 nM
Compound 3: middle estimate off by 13-fold (1.10 log units), on the high side; the measured number lies below the stated range.
By their numbers in this assay, from the lowest: compounds 3 and 1 (each within the scatter of the next); then compound 2.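

In this assay, replacing 3-chlorophenyl with 4-fluorophenyl on this saturated chain carbon gives a 7.9-fold lower number from compound 2 to compound 3 (0.90 log units; beyond the scatter) with the rest of the molecule unchanged. This position therefore responds to the choice of aryl group, even though both groups have the same heavy-atom count and one aromatic ring of carbon. Nothing measured here explains the step. The halogen and its place on the ring change together, so neither can be credited alone. On these data alone, whether 3-fluorophenyl, unsubstituted phenyl or 4-methoxyphenyl would behave like 4-fluorophenyl remains open.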